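Swapping a dichlorophenyl for a nitrophenyl on a fused core

A few compounds are considered here, and "the series" means these few. Any claim that something is new, unique, unknown or untested is made for them only; others in the source may bear on it.

Of the compounds shown here, two have been measured in a functional assay on Huh-7 cells (Homo sapiens) for inhibition, read by sulforhodamine B assay, with a stated time of 72 h; on this read-out higher numbers stand for weaker inhibition and lower numbers for stronger inhibition. Compound 1, with the structure `CC(C)Cc1ccc(C(C)c2n[nH]c(=S)n2N)cc1`, gives 23000 nM in this assay. Compound 2, with the structure `CC(c1ccc(-c2ccccc2)c(F)c1)c1nnc2n1N=C(c1ccc(Cl)cc1Cl)CS2`, gives 3700 nM in this assay, the lower of the two numbers, and the gap to compound 1 lies beyond the usual scatter of repeated measurements.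

Compound 3, with the structure `CC(c1ccc(-c2ccccc2)c(F)c1)c1nnc2n1N=C(c1ccc([N+](=O)[O-])cc1)CS2`, has not yet been measured. It differs from compound 2 in one place: 4-nitrophenyl in place of 2,4-dichlorophenyl on a carbon with a double bond to nitrogen. Within the data shown here, no pair of measured compounds shows what such a swap does, so there is no measured step to lean on.

Without such a reference, the expected step from compound 2 to compound 3 is a 1.4-fold higher number from compound 2 to compound 3 (0.13 log units; within the scatter), a small shift toward a somewhat higher number that may well stay within the scatter. Compound 3 is therefore estimated to give about 5000 nM in this assay, with a likely range from 1500 nM to 15000 nM.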

Compound 3, half-maximal inhibitory concentration: 4300 nM
Estimate against measurement, compound 3: 1.2-fold (0.07 log units) above; the measured number falls inside the stated range.
By their numbers in this assay, from the lowest: compounds 2 and 3 (each within the scatter of the next); then compound 1.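

In this assay, among these compounds, putting 4-nitrophenyl in place of 2,4-dichlorophenyl gives a 1.2-fold higher number from compound 2 to compound 3 (0.07 log units; within the scatter) and so provides the first measured step at this carbon with a double bond to nitrogen. Here, the two chlorine atoms leave and a group with one nitrogen and two oxygen atoms enters, yet the two compounds cannot be told apart in this assay. The six-membered aromatic ring of carbon stays in both, and nothing measured here explains why the swap leaves the reading within the scatter.

From the compounds shown here alone, it remains open whether an amine or a carboxylic acid on this aromatic ring would also leave the number within the scatter. A plain phenyl ring without any added group would show whether the chlorine atoms or the nitro group matter at all.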